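A Second Chloro on the Fused Ring: What to Expect

A few compounds are considered here, and "the series" means these few. Any claim that something is new, unique, unknown or untested is made for them only; others in the source may bear on it.

Compound 1 `COC(=O)c1ccc(N)c(-c2nc3ccccc3n(Cc3ccccc3)c2=O)c1`: 550 nM
Compound 2 `O=c1c(-c2cccc([N+](=O)[O-])c2)nc2ccc(Cl)cc2n1Cc1ccccc1`: 760 nM

Of the compounds shown here, two have been measured so far in an assay on cells for activation of Cystic fibrosis transmembrane conductance regulator (Homo sapiens), read by fluorescence, with a stated time of 10 min; a lower number here means that less compound is needed, a higher number that more compound is needed for the effect. Compound 1 gives 550 nM, and compound 2 gives 760 nM. Of the two, compound 2 has the higher number, but the gap to compound 1 is within the scatter, so the two cannot be told apart on this evidence.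

Compound 3 `O=c1c(-c2cccc([N+](=O)[O-])c2)nc2cc(Cl)c(Cl)cc2n1Cc1ccccc1` is the next compound to be measured. It differs from compound 2 in one place: chloro in place of hydrogen on an aromatic carbon. The new chloro sits on the six-membered carbon ring of the fused core, ortho to the chloro group already present, meta to the fused ring and para to the fused ring.

Within the data shown here, no measured pair shows what such an added chloro does here, so the expectation rests on compound 2 alone. A single added chloro on an aromatic ring is a small change, and the expected step from compound 2 to compound 3 is estimated as a 1.3-fold lower number from compound 2 to compound 3 (0.10 log units; within the scatter), likely no larger than the scatter. Compound 3 is therefore expected to give about 600 nM in this assay, with a range from 250 nM to 1800 nM.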

Compound 3, half-maximal effective concentration: > 10000 nM
Compound 3: a limit, no number; the forecaster's own chance of this, stated with the estimate: 5%; middle value at least 16-fold (1.22 log units) from the limit.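

In this assay, chloro in place of hydrogen on this aromatic carbon, ortho to the chloro group already present, proves to be far from a small change: it brings an at least 13-fold higher number from compound 2 to compound 3 (1.11 log units; beyond the scatter). Compound 3 stands as a limit of the assay and not as a number: the limit of > 10000 nM in this assay, at which 1 of the 3 values shown sits. In this one pair, then, a single added heavy atom at this position of the shared core is enough to take a compound with a measurable value to one with none, something that compound 1 and compound 2, which differ in more than one place, could not show.

From the compounds shown here alone, it stays open whether this loss belongs to the position itself or to the two chloro groups standing together, and how far the true value of compound 3 lies past the limit cannot be read. Nor do the compounds shown tell whether a fluoro, a methoxy or an amine on this same carbon would keep a measurable value, or whether the same chloro would act alike on the core of compound 1.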